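Swapping Cyano for Chloro in Compound 1

The source may report more compounds than this note shows. Statements on the series, on what has been measured and on what is new or still open speak of the compounds shown alone.

Measured in an ADME assay on microsomes from liver (Mus musculus) for metabolic stability, read by LC-MS, using NADPH, with a stated time of 10 min, tested at 10 uM; a higher number here means that the compound lasts longer, a lower number that the compound disappears faster:
- compound 1 `N#Cc1ccnc(Oc2nn(C3CCC3)c3ncnc(N)c23)c1`: 0.4 h
- compound 2 `Nc1ncnc2c1c(Oc1cc(C(F)(F)F)ccn1)nn2C1CC1`: > 2.41 h (a limit of the assay, not a number)
- compound 3 `N#Cc1ccnc(Oc2nn([C@H]3C[C@H](O)C3)c3ncnc(N)c23)c1`: > 2.41 h (a limit of the assay, not a number)

Within the data shown here, compound 1 has the only true number in this small set, 0.4 h. From the compounds shown here alone, the other two compounds stand at the limit of > 2.41 h in this assay, at which 2 of the 3 values shown sit, so their exact half-lives remain unknown.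

The next compound to be tested is compound 4 `Nc1ncnc2c1c(Oc1cc(Cl)ccn1)nn2C1CCC1`. It differs from compound 1 by a single swap: chloro in place of cyano on an aromatic carbon. In words, chloro takes the place of cyano on an aromatic carbon, opposite the ring nitrogen.

One measured step starts from compound 1: an at least 6.0-fold higher number from compound 1 to compound 3 (0.77 log units; beyond the scatter). That step puts hydroxy in place of hydrogen on a saturated ring carbon, which is a different change at a different place, so it does not bear directly on this swap. Among the measured compounds shown here, no measured step covers a change of cyano to chloro.

With no direct evidence, the expectation in this assay stays close to compound 1 at 0.4 h, with no step beyond the scatter in either direction. The expected change is a 1.3-fold higher number from compound 1 to compound 4 (0.10 log units; within the scatter). For compound 4 the estimated half-life is 0.5 h, with an expected range from 0.17 h to 1.5 h.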

Compound 4, half-life: 0.0617 h
Compound 4: the middle estimate sits 8.1-fold (0.91 log units) above what was measured; measured number below the stated range.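

In this assay, the group on the aromatic carbon opposite the ring nitrogen proves to matter, since putting chloro in place of cyano gives a 6.5-fold lower number from compound 1 to compound 4 (0.81 log units; beyond the scatter). Among these compounds, the only earlier step from compound 1 changed a saturated ring carbon and gave an at least 6.0-fold higher number from compound 1 to compound 3 (0.77 log units; beyond the scatter), so the half-life is now seen to respond at two different places, in opposite directions for these two changes. Nothing measured here explains why the half-life falls with this swap, and one pair of compounds cannot turn it into a rule for this position.

From the compounds shown here alone, it remains open how other groups on this aromatic carbon, such as methoxy, an amine or a carboxylic acid, would compare with cyano and chloro. It is also open whether hydroxy on the saturated ring would give a longer half-life when chloro rather than cyano sits on the aromatic ring, as the compounds shown do not combine those two changes.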